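This account rests on a few compounds, and the source may have more. Where it says the series, first, only, none or still open, it means among the compounds named here.

Working notes on the series. Compound 1 `CC(=O)N[C@@H](C)C(=O)N(C)/N=N/c1ccc(Br)cc1` gives 5.7 h in an ADME assay on a cell-free system (plasma, Homo sapiens) for metabolic stability, read by HPLC; a higher number here means that the compound lasts longer, a lower number that the compound disappears faster. Compound 3 `CC(=O)N[C@H](C(=O)N(C)/N=N/c1ccc(C#N)cc1)C(C)C` gives 5.7 h in this assay, level with compound 1 at the digits shown, and together these two carry the highest numbers of the three measured. Compound 2 `CCC(=O)N[C@@H](C)C(=O)N(C)/N=N/c1ccc(C#N)cc1` gives 1.3 h in this assay, a lower number than compound 1 and beyond the scatter, so compound 2 stands furthest from compound 1. For the measured compounds named here, no two measured compounds differ in a single place, so no step between measured compounds is available to lean on.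

Compound 4 `CC(=O)N[C@@H](C)C(=O)N(C)/N=N/c1ccc(C)cc1` has not yet been measured in this assay. It differs from compound 1 by methyl in place of bromo on an aromatic carbon. The measured compounds give no comparable exchange, and the part of compound 1 where compound 2 differs from it is left untouched by this change. The expectation is that a 1.3-fold lower number from compound 1 to compound 4 (0.10 log units; within the scatter) stays within the scatter, with only a slight lean downward. Compound 4 is accordingly estimated at 4.5 h, with a range from 2 h to 10 h.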

Compound 4, half-life: 15.1 h
The estimate for compound 4 lay 3.4-fold (0.53 log units) below the measured number, and the stated range ends below it.
By their numbers in this assay, from the lowest: compound 2; then compounds 1 and 3 (each within the scatter of the next); then compound 4.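

Methyl in place of bromo on an aromatic carbon, para to a large group, gives a 2.6-fold higher number from compound 1 to compound 4 (0.42 log units; beyond the scatter) in this assay; as the only step in the series that changes a single place, it shows that this position alone can move the number beyond the scatter. One heavy atom leaves and one enters, with no change in hydrogen-bond donors, hydrogen-bond acceptors or net charge, so these counts do not separate compound 1 from compound 4. No measurement at hand accounts for the step.

From the compounds shown here alone, how other groups at this position, such as chloro, methoxy or an amine, would compare with methyl and bromo remains open. Also open, going by these compounds, is whether the same exchange gives a step of similar size with a different acyl chain or amino acid side chain.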